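The source may hold more compounds than are shown below. What is called first, only, known or untested is meant among the compounds shown, and "the series" means these compounds.

Measured compounds in a functional assay on PHA-Ly cells (Homo sapiens); on this read-out higher numbers stand for weaker inhibition and lower numbers for stronger inhibition:
- compound 1, `CNc1nc(SC)nc2c1ncn2[C@@H]1C[C@@H](O)[C@H](CO)O1`: 81 uM
- compound 2, `CN(C)c1nc(N)c2ncn([C@@H]3C[C@@H](O)[C@H](CO)O3)c2n1`: > 300 uM
- compound 3, `CNc1nc(Br)nc2c1ncn2[C@@H]1C[C@@H](O)[C@H](CO)O1`: 30 uM

Compound 1 stands at the highest of the two numbers in this assay; its nearest neighbour is compound 3, with a 2.7-fold lower number from compound 1 to compound 3 (0.43 log units; beyond the scatter). For compound 2 this assay reports only a limit, > 300 uM, and no number, as noted in the limit of > 300 uM in this assay, at which 1 of the 3 values shown sits.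

The step from compound 1 to compound 4, `CSc1nc(N(C)C)c2ncn([C@@H]3C[C@@H](O)[C@H](CO)O3)c2n1`, is methyl in place of hydrogen on a nitrogen on an aromatic ring. Among the measured compounds shown here, no measured step touches that nitrogen: the one measured step, from compound 1 to compound 3, changes a group on an aromatic carbon, so it gives no direct guide. Compound 2, which carries a dimethylamino group, gives only a limit in this assay rather than a number, while compound 1 gives a number. On that basis compound 4 is expected to give a higher number, with a 2.5-fold higher number from compound 1 to compound 4 (0.39 log units; beyond the scatter), and quite possibly only a limit. The estimate for compound 4 in this assay is 200 uM, within 60 uM to 600 uM.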

Compound 4, concentration for 50% inhibition: 260 uM
Estimate against measurement, compound 4: 1.3-fold (0.11 log units) below; the range from low to high includes it.
By their numbers in this assay, from the lowest: compound 3; then compound 1; then compound 4. At a limit, above all of these: compound 2.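

Methyl in place of hydrogen on a nitrogen on an aromatic ring gives, in this assay, a 3.2-fold higher number from compound 1 to compound 4 (0.51 log units; beyond the scatter), the first measured step at this nitrogen. Going from methylamino to dimethylamino thus moves the number towards weaker inhibition, while compound 4, with the methylsulfanyl group kept, still gives a number and not a limit. Compound 2, which also carries dimethylamino but has an amino group where compound 4 has methylsulfanyl, gives only a limit: the limit of > 300 uM in this assay, at which 1 of the 4 values shown sits.

The compounds shown place only methylamino and dimethylamino on this side of the core, so this single step cannot say how a free amino group or a longer chain such as ethyl on that nitrogen would read in this assay. From the compounds shown here alone, whether the same step holds with bromo in place of methylsulfanyl also stays open.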